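Replacing 4-methylbenzyl with propyl on sulfur

The source may report more compounds than this note shows. Statements on the series, on what has been measured and on what is new or still open speak of the compounds shown alone.

In a toxicity assay on GES1 cells (Homo sapiens) for inhibition, read by MTT assay, with a stated time of 72 h (on this read-out higher numbers stand for weaker inhibition and lower numbers for stronger inhibition), compound 1 `C=CCSc1nc2nc(C)cc(N3CC[C@@H](C)[C@@H](N(C)c4ncnc5[nH]ccc45)C3)n2n1` gives > 100000 nM as a limit of the assay and not a number. Going by the values given here, compound 2 `Cc1ccc(CSc2nc3nc(C)cc(N4CC[C@@H](C)[C@@H](N(C)c5ncnc6[nH]ccc56)C4)n3n2)cc1` gives 82500 nM as the only actual number so far. Compound 3 `CCCSc1nc2nc(C)cc(N3CC[C@@H](C)[C@@H](N(C)c4ncnc5[nH]ccc45)C3)n2n1` is still unmeasured. Going to it from compound 2, the change is ethyl in place of 4-methylphenyl on a saturated chain carbon bound to a sulfur and amounts to ethyl in place of 4-methylphenyl on a saturated chain carbon bound to a sulfur. Among the compounds with values here, the one measured step at this place is an at least 1.2-fold lower number from compound 1 to compound 2 (0.08 log units; that floor lies within the scatter) and it brought in that same 4-methylphenyl group. With compound 2 at 82500 nM and that step not shown to lie beyond the scatter, removing the group is expected to shift the number in this assay little, and upward if at all. The expected change is a 1.2-fold higher number from compound 2 to compound 3 (0.08 log units; within the scatter) and is estimated to stay small. Compound 3 is estimated at 100000 nM with an expected range of 50000 nM to 200000 nM.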

Compound 3, half-maximal inhibitory concentration: 67100 nM
Compound 3: the middle estimate sits 1.5-fold (0.17 log units) above what was measured; the range from low to high includes it.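

Putting ethyl in place of 4-methylphenyl on a saturated chain carbon bound to a sulfur gives a 1.2-fold lower number from compound 2 to compound 3 (0.09 log units; within the scatter) in this assay. Going by these compounds alone, this is the first step at this place read between two actual numbers, and it shows that losing the six-membered aromatic ring leaves the number within the scatter. Ethyl in place of vinyl on that same carbon gives an at least 1.4-fold lower number from compound 1 to compound 3 (0.17 log units; that floor lies within the scatter), and this comparison stays a floor because one end of it is a limit: the limit of > 100000 nM in this assay, at which 1 of the 3 values shown sits.

The groups shown on the sulfur hold carbon only, so it remains open whether an amine or a carboxylic acid on the chain would move the number in this assay beyond the scatter. Going by these compounds, it is also open whether a longer chain would do so.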